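The source may report more compounds than this note shows. Statements on the series, on what has been measured and on what is new or still open speak of the compounds shown alone.

Compound 1 `COc1cc2c(=O)c(C(=O)c3ccc(C)cc3)cn(Cc3ccc(C(F)(F)F)cc3F)c2cc1OC` is one of three compounds examined in an ADME assay on Huh-7 cells (Homo sapiens) for cytotoxicity; on this read-out higher numbers stand for weaker inhibition of growth and lower numbers for stronger inhibition of growth. In this assay compound 1 reaches only a limit of the assay, > 25000 nM, and not a number. Compound 2 `CN1CCN(c2cc3c(cc2F)c(=O)c(NC(=O)NCc2ccc(Cl)cc2)cn3Cc2ccc(Cl)cc2)CC1` is reported in this assay as "not active" (no number reported). Compound 3 `COc1cc2c(=O)c(S(=O)(=O)CCc3ccc(Cl)cc3)cn(Cc3ccccc3)c2cc1OC` is reported in this assay as "not active" (no number reported). For the measured compounds named here, compound 1 therefore stands at the limit of > 25000 nM in this assay, at which 1 of the 3 values shown sits, and the two other entries give no number at all; none of the three shows growth inhibition within the measured range, so no step between measured compounds can be counted.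

Compound 4 `COc1cc2c(=O)c(C(=O)c3ccc(C)cc3)cn(CCCc3ccccc3)c2cc1OC` has not yet been measured in this assay. It differs from compound 1 in a single place: phenethyl in place of 2-fluoro-4-(trifluoromethyl)phenyl on a saturated chain carbon bound to an aromatic nitrogen. Going by the values given here, no measured pair shows how such a change moves this assay, and the only anchor is the limit at which compound 1 sits. The step from compound 1 to compound 4 is therefore expected to lie within the scatter, with no direction favoured beyond it. Compound 4 is expected to give 25000 nM in this assay, with a range from 10000 nM to 100000 nM, and the assay is most probably going to report only a limit again. The expected step that this estimate means is a number no higher from compound 1 to compound 4 (the limit leaves the size open), within the scatter.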

Compound 4, concentration for 50% growth inhibition: "not active" (no number reported)
Nothing numeric was reported for compound 4, and the estimate cannot be compared.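

For the compounds shown here, no step from compound 1 to compound 4 can be read in this assay: compound 4 is reported as "not active" without a number, and compound 1 gives only a limit of the assay. The compounds shown leave open how strongly any of them inhibits growth, and whether 3-phenylpropyl and 2-fluoro-4-(trifluoromethyl)benzyl differ at all on this read-out.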